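The compounds below may be only part of what the source reports. "The series", "measured", "known", "first", "only" and "open" are said of these compounds alone.

Compound 1 `Cc1ccnc([C@@H](C)Oc2cc3oc(=O)n(CCC(=O)O)c3cc2Cl)c1` – 2.15
Compound 2 `O=C(O)CCn1c(=O)oc2cc(OCc3ccccn3)c(Cl)cc21` – 1.32

Of the compounds shown here, two have been measured in a physicochemical assay for lipophilicity, read by HPLC, at pH 7.4; a higher number here means a more lipophilic compound, a lower number a more polar compound. Compound 1 gives 2.15 in this assay, and compound 2 gives 1.32. Compound 1 thus holds the higher of the two numbers, and the gap to compound 2 lies beyond the usual scatter of this assay, so compound 1 is the more lipophilic of the pair. Among the measured compounds shown here, no step between these two is broken down into a single structural change, so only the two values themselves can be compared.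

Compound 3 `C[C@@H](Oc1cc2oc(=O)n(CCC(=O)O)c2cc1Cl)c1ccc(Cl)cn1` has not yet been measured. It differs from compound 1 in one place: 5-chloropyridin-2-yl in place of 4-methylpyridin-2-yl on a saturated chain carbon bound to an oxygen on an aromatic ring and a saturated chain carbon

Both groups that swap are six-membered aromatic rings of the same heavy-atom count with one hydrogen-bond acceptor and no donor, so the shared core and the acid chain stay untouched. On the two values at hand, a small upward step is expected from compound 1 to compound 3 in this assay, at the edge of the scatter: a number 0.20 log units higher from compound 1 to compound 3 (within the scatter). Compound 3 is therefore estimated to give 2.35 in this assay, expected between 1.95 and 2.75.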

Compound 3, distribution coefficient: 2.65
Compound 3: middle estimate off by 0.30 log units, on the low side, and the stated range covers the measured number.
By their numbers in this assay, from the lowest: compound 2; then compound 1; then compound 3.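

Within this assay, putting 5-chloropyridin-2-yl in place of 4-methylpyridin-2-yl on this saturated chain carbon gives a number 0.50 log units higher from compound 1 to compound 3 (beyond the scatter). Among the compounds shown here, this is the first change that can be read at a single place, and it shows that the number at this position can move beyond the scatter even though the two groups have the same heavy-atom count, the same hydrogen-bond donor and acceptor counts, and no net charge. Nothing measured here explains why the number moves.

The swap changes two things at once, since the methyl group leaves the ring and a chlorine enters it under a different number in the group's name, so the compounds shown cannot say how much of the step belongs to the chlorine, to the loss of the methyl group, or to where each one sits. A 5-methylpyridin-2-yl or 4-chloropyridin-2-yl group at this same place would separate these parts, and a 5-methoxypyridin-2-yl group would show how another substituent compares with the chlorine.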